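This account rests on a few compounds, and the source may have more. Where it says the series, first, only, none or still open, it means among the compounds named here.

Compound 1 `O=C1c2c[n+]([O-])c3ccccc3c2C(=O)c2c1c1ccccc1n2CCCCN1CCNCC1` is one of three compounds sharing a core in which an amine-bearing chain hangs from an aromatic nitrogen. In a functional assay on SH-SY5Y cells (Homo sapiens) for cytotoxicity, read by MTT assay, with a stated time of 72 h (on this read-out lower numbers stand for stronger inhibition and higher numbers for weaker inhibition), compound 1 gives 1240 nM, the highest of the two numbers shown. Compound 3 `O=C1c2c[n+]([O-])c3ccccc3c2C(=O)c2c1c1ccccc1n2Cc1cn([C@H]2C[C@H](O)[C@@H](CO)O2)nn1` gives 620 nM in this assay, and the gap to compound 1 lies within the scatter. Compound 2 `CC1(C)O[C@@H](CO)[C@H](Cn2cc(Cn3c4c(c5ccccc53)C(=O)c3c[n+]([O-])c5ccccc5c3C4=O)nn2)O1` reaches only a limit, > 1000 nM, in this assay. Among the compounds with values here, the one measured step, an at least 1.6-fold lower number from compound 2 to compound 3 (0.20 log units; that floor lies within the scatter), concerns the group on the aromatic nitrogen (the limit of > 1000 nM in this assay, at which 1 of the 3 values shown sits). Compound 4 `CN1CCN(CCCCCn2c3c(c4ccccc42)C(=O)c2c[n+]([O-])c4ccccc4c2C3=O)CC1` differs from compound 1 by (4-methylpiperazin-1-yl)methyl in place of piperazin-1-yl on a saturated chain carbon, four bonds along the chain from an aromatic nitrogen. Within the data shown here, no measured step touches this part of the molecule, so no change beyond the scatter is expected. Compound 4 is estimated at 1000 nM, between 300 nM and 3500 nM, which is expected to mean a 1.2-fold lower number from compound 1 to compound 4 (0.09 log units; within the scatter).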

Compound 4, half-maximal inhibitory concentration: 830 nM
Compound 4: middle estimate off by 1.2-fold (0.08 log units), on the high side; the range from low to high includes it.
By their numbers in this assay, from the lowest: compounds 3, 4 and 1 (each within the scatter of the next).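

Replacing piperazin-1-yl with (4-methylpiperazin-1-yl)methyl gives, in this assay, a 1.5-fold lower number from compound 1 to compound 4 (0.17 log units; within the scatter). Within the data shown here, no earlier step touched this part of the molecule, and this one shows that the number stays within the scatter even though the hydrogen-bond donor of piperazin-1-yl is gone and the group is larger. Nothing measured here bears on this result. The added methyl and the extra chain carbon enter together, so the compounds shown cannot separate them. Also open, on these data alone, is how a morpholine ring or a carboxylic acid at the end of this chain would read.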